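The source may report more compounds than this note shows. Statements on the series, on what has been measured and on what is new or still open speak of the compounds shown alone.

In an ADME assay on MT4 cells (Homo sapiens) for cytotoxicity, read by MTT assay, with a stated time of 5 days (a higher number here means that more compound is tolerated, a lower number that less compound is tolerated), compound 1 (`Cc1cc(C)cc(S(=O)(=O)c2c(C(=O)NC3CN(Cc4cccnc4)C3)[nH]c3ccc(Cl)cc23)c1`) gives 36000 nM. Compound 2 (`CCS(=O)(=O)NC(=O)c1[nH]c2ccc(Cl)cc2c1S(=O)(=O)c1cc(C)cc(C)c1`) has no exact number in this assay: its entry, > 283000 nM, is a limit of the assay. That entry is the limit of > 283000 nM in this assay, at which 1 of the 2 values shown sits. On these data alone, its exact position therefore remains unknown.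

Compound 3 (`CCCS(=O)(=O)NC(=O)c1[nH]c2ccc(Cl)cc2c1S(=O)(=O)c1cc(C)cc(C)c1`) differs from compound 2 by one small change, (methyl in place of hydrogen on a saturated chain carbon, two bonds along the chain from a sulfonyl sulfur). This places methyl in place of hydrogen on a saturated chain carbon, two bonds along the chain from a sulfonyl sulfur, so that ethylsulfonyl becomes propylsulfonyl.

Going by the values given here, only one measured step bears on this change, and it bears on it weakly. That step, an at least 7.8-fold higher number from compound 1 to compound 2 (0.89 log units; beyond the scatter), exchanged a whole substituent and does not measure the addition of one methyl. With nothing pointing to a shift, no step beyond the scatter is expected in this assay, and the assay may again report only a limit. The expected step, an at least 1.0-fold lower number from compound 2 to compound 3 (0.03 log units; that floor lies within the scatter), is an estimate that rests on this reasoning. For compound 3 the estimated value is 260000 nM, with an expected range from 90000 nM to 400000 nM.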

Compound 3, half-maximal cytotoxic concentration: 146000 nM
The estimate for compound 3 lay 1.8-fold (0.25 log units) above the measured number; the measured number falls inside the stated range.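

In this assay, adding methyl on a saturated chain carbon, two bonds along the chain from a sulfonyl sulfur, turns ethylsulfonyl into propylsulfonyl and gives an at least 1.9-fold lower number from compound 2 to compound 3 (0.28 log units; that floor lies within the scatter), so this small change can be followed only as a lower bound that does not clear the scatter. On these data alone, the entry for compound 2 is a limit of the assay, and the true size of the methyl step therefore remains unknown: the limit of > 283000 nM in this assay, at which 1 of the 3 values shown sits. What the exact number for compound 3 adds is a measured size for exchanging 1-((pyridin-3-yl)methyl)azetidin-3-yl for a sulfonyl group on the amide-type nitrogen, which the earlier pair could only bound: a 4.1-fold higher number from compound 1 to compound 3 (0.61 log units; beyond the scatter).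

The compounds shown leave open whether the number keeps moving in the same direction along a longer chain such as butylsulfonyl, since a single methyl step of unknown size sets no trend. They also leave open what a carboxylic acid or an amine at the end of the propyl chain would do in this assay.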